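Series notes: from compound 1 to compound 4

This account rests on a few compounds, and the source may have more. Where it says the series, first, only, none or still open, it means among the compounds named here.

Compound 1 `COc1ccc(C(=O)NC(=S)Nc2cccc(-c3nc4ccccc4[nH]3)c2)cc1OC` in a functional assay on HUVEC cells (Homo sapiens) for cytotoxicity, read by WST assay, with a stated time of 48 h (on this read-out higher numbers stand for weaker inhibition and lower numbers for stronger inhibition), gives 6000 nM, the lowest of the three numbers in hand. Compound 2 `COc1ccc(C(=O)NC(=O)Nc2cccc(-c3nc4ccccc4[nH]3)c2)cc1OC` gives 8000 nM and compound 3 `CCOc1ccc(C(=O)NC(=S)Nc2cccc(-c3nc4ccccc4[nH]3)c2)cc1OCC` gives 8000 nM; both sit within the scatter of compound 1, so the three cannot be ranked on these numbers. Compound 4 `O=C(NC(=S)Nc1cccc(-c2nc3ccccc3[nH]2)c1)c1ccc2c(c1)OCCO2` differs from compound 1 in one place: 2,3-dihydro-1,4-benzodioxin-6-yl in place of 3,4-dimethoxyphenyl on a carbonyl carbon. Among the compounds with values here, no step between two measured compounds bears on this change, and the measured values give no direction beyond the scatter. The step from compound 1 to compound 4 is expected to be no change at the digits printed from compound 1 to compound 4 (within the scatter), that is, no change beyond the scatter. Compound 4 is estimated at 6000 nM in this assay, with a range from 3000 nM to 12000 nM.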

Compound 4, half-maximal inhibitory concentration: 50 nM
For compound 4 the middle estimate is 120-fold (2.08 log units) above the measured one; measured number outside the range, below it.
By their numbers in this assay, from the lowest: compound 4; then compounds 1, 2 and 3 (each within the scatter of the next).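

Within the data shown here, replacing 3,4-dimethoxyphenyl with 2,3-dihydro-1,4-benzodioxin-6-yl on a carbonyl carbon gives a 120-fold lower number from compound 1 to compound 4 (2.08 log units; beyond the scatter) in this assay, so this position responds strongly, which the earlier compounds did not show. The two groups have the same heavy-atom, donor and acceptor counts and differ in the added non-aromatic ring. No measured evidence on the origin of the step is available.

Open, from the compounds shown here alone, is whether other ring-closed groups, such as 1,3-benzodioxol-5-yl, on the same carbonyl carbon give a similar step. Also open, going by these compounds, is whether the same replacement carries over to the core of compound 2.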